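Nitrophenoxy Replaces Cyclohexyl on an Inactive Amide

This account rests on a few compounds, and the source may have more. Where it says the series, first, only, none or still open, it means among the compounds named here.

Of the compounds shown here, three have been tested in a functional assay on HepG2 cells (Homo sapiens) for antiproliferative activity, with a stated time of 72 h; a higher number here means that more compound is needed for the effect, a lower number that less compound is needed. Compound 1 `COC(=O)c1cc(=O)c2c(OC)cc(OC)cc2n1C` reaches only the limit of the assay, > 19000 nM. Compound 2 `COc1ccc(-c2cc(=O)c3c(OC)cc(OC)cc3n2S(=O)(=O)c2cc(Cl)cc(Cl)c2O)cc1` likewise gives only a limit, > 37900 nM. Compound 3 `COc1cc(OC)c2c(=O)cc(C(=O)Nc3ccc(C4CCCCC4)cc3)[nH]c2c1` also returns only a limit in this assay, > 43100 nM. Since every value is a limit, nothing separates compound 3 from the other two, and its standing is simply that of a compound at the limit (the limit of > 43100 nM in this assay, at which 1 of the 3 values shown sits). Compound 4 `COc1cc(OC)c2c(=O)cc(C(=O)Nc3ccc(Oc4ccc([N+](=O)[O-])cc4)cc3)[nH]c2c1` has not yet been measured. It differs from compound 3 by 4-nitrophenoxy in place of cyclohexyl on an aromatic carbon. Among the measured compounds shown here, no step between two measured compounds exists, so no direction and no size can be read from a comparison; the three limits carry no trend. Compound 4 is therefore expected to stay close to the limit, the step being estimated as an at least 1.0-fold lower number from compound 3 to compound 4 (0.03 log units; that floor lies within the scatter). The estimate for compound 4 is 40000 nM, within 15000 nM to 120000 nM.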

Compound 4, half-maximal effective concentration: > 22900 nM
Compound 4 was reported as a limit (the forecaster's own chance of this, stated with the estimate: 70%); the middle value does not contradict the limit.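

Compound 3 and compound 4 both stand as limits in this assay, so no step can be read for 4-nitrophenoxy in place of cyclohexyl: the limit of > 22900 nM in this assay, at which 1 of the 4 values shown sits.

The compounds shown leave open whether any change to the shared core gives a measurable value in this assay.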